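A few compounds are considered here, and "the series" means these few. Any claim that something is new, unique, unknown or untested is made for them only; others in the source may bear on it.

Measured so far:
- compound 1, `C=C1CC[C@H]2C(C)(C)CCC[C@]2(C)[C@H]1C/C=C1/C(=O)OC[C@H]1O`: 95.6%
- compound 2, `C=C1CC[C@H]2C(C)(C)CCC[C@]2(C)[C@H]1C[C@@H](O)C1=CCOC1=O`: 111%
- compound 3, `C=C1CC[C@H]2C(C)(C)CCC[C@]2(C)[C@H]1C/C=C1\CC(O)OC1=O`: 92.7%

All three share the same terpene-like core and differ only in the lactone-bearing end of the molecule. In an ADME assay on RAW264.7 cells (Mus musculus) for cytotoxicity, read by luminescence and CellTiter-Glo, with a stated time of 18 h, tested at 1 uM (a higher number here means a weaker effect of the compound at the concentration tested, a lower number a stronger effect), compound 1 gives 95.6%, compound 2 gives 111% and compound 3 gives 92.7%. Compound 3 holds the lowest of the three numbers, but its gap to compound 1 lies within the scatter of the method, while its gap to compound 2 lies beyond it. All three numbers sit near the level of untreated cells, so none of these compounds shows a strong effect at the concentration tested.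

Compound 4, `C=C1CC[C@H]2C(C)(C)CCC[C@]2(C)[C@H]1C/C=C1\CC(OC)OC1=O`, has not yet been measured. It differs from compound 3 in one place: methyl in place of hydrogen on an oxygen on a saturated carbon. Among the compounds with values here, no step of this kind is known among the measured compounds, so the expectation rests on the flat picture above. Given how close compound 3 sits to compound 1 in this assay, a step from compound 3 to compound 4 of a number 2.3 percentage points higher from compound 3 to compound 4 (within the scatter) is expected, that is, nothing beyond the scatter. Compound 4 is therefore estimated at 95%, with a range from 82% to 108%.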

Compound 4, a percentage reported as activity, at one concentration (the size of the read-out at that concentration, not a potency): 102%
Compound 4: the middle estimate sits 7 percentage points below what was measured; the range from low to high includes it.
By their numbers in this assay, from the lowest: compounds 3, 1, 4 and 2 (each within the scatter of the next, the first and the last beyond it).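

The pair compound 3 and compound 4 gives the first direct test of this position, on an oxygen on a saturated carbon: in this assay, the change from hydroxy to methoxy comes with a number 9.3 percentage points higher from compound 3 to compound 4 (within the scatter) and so makes no clear difference. The hydrogen on this oxygen is therefore not needed to keep the read-out at this level, and one added methyl is tolerated here, although a compound with little effect at this single concentration has little effect to lose. Nothing among the available data explains this result.

A longer chain on this oxygen, such as ethyl or benzyl, or an amine in place of the hydroxy, could still behave differently. Going by these compounds, whether hydroxy and methoxy would also match at higher concentrations, where a clearer effect on the cells might appear, remains open too.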